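Toward a Fluorinated Analogue of a Chalcone-Amide Series

This account rests on a few compounds, and the source may have more. Where it says the series, first, only, none or still open, it means among the compounds named here.

Measured so far in a functional assay on B16 cells (Mus musculus) for cytotoxicity, read by MTT assay, with a stated time of 72 h; on this read-out higher numbers stand for weaker inhibition and lower numbers for stronger inhibition:
compound 1 `COc1ccc(C(=O)c2cc(OC)c(OC)c(OC)c2)cc1NC(=O)/C=C/c1cc(OC)c(OC)c(OC)c1` gives 1200 nM
compound 2 `COc1ccc(/C=C/C(=O)Nc2cc(C(=O)c3cc(OC)c(OC)c(OC)c3)ccc2OC)cc1` gives 8700 nM
compound 3 `COc1cccc(/C=C/C(=O)Nc2cc(C(=O)c3cc(OC)c(OC)c(OC)c3)ccc2OC)c1` gives 3100 nM

Among these three numbers compound 3 stands second highest: compound 1 sits nearest, with a 2.6-fold higher number from compound 1 to compound 3 (0.41 log units; beyond the scatter), while compound 2 sits furthest, with a 2.8-fold lower number from compound 2 to compound 3 (0.45 log units; beyond the scatter). Compound 4 `COc1ccc(C(=O)c2cc(OC)c(OC)c(OC)c2)cc1NC(=O)/C=C/c1ccc(F)cc1` has not yet been measured. It differs from compound 3 by 4-fluorophenyl in place of 3-methoxyphenyl on a double-bonded chain carbon bound to a double-bonded chain carbon.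

For the measured compounds named here, two measured steps bear on this change. The step of a 7.3-fold higher number from compound 1 to compound 2 (0.86 log units; beyond the scatter) shows that removing methoxy groups from that ring raises the number modestly, and the step of a 2.8-fold lower number from compound 2 to compound 3 (0.45 log units; beyond the scatter) shows that the ring bearing a single substituent at the 4-position gives the higher number. Both point the same way, so compound 4 is expected to give a modestly higher number than compound 3, a 2.1-fold higher number from compound 3 to compound 4 (0.32 log units; beyond the scatter). The estimate for compound 4 in this assay is 6500 nM, in the range 2500 nM to 18000 nM.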

Compound 4, half-maximal inhibitory concentration: 400 nM
Compound 4: the middle estimate sits 16-fold (1.21 log units) above what was measured; the whole stated range lies above it.
By their numbers in this assay, from the lowest: compound 4; then compound 1; then compound 3; then compound 2.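

In this assay, for the compounds shown here, the earlier compounds tied a lower number to more methoxy groups on this ring, but 4-fluorophenyl, with none, goes against that pattern: a 7.8-fold lower number from compound 3 to compound 4 (0.89 log units; beyond the scatter) and a 3.0-fold lower number from compound 1 to compound 4 (0.48 log units; beyond the scatter). A single substituent at the 4-position does not itself bring a high number, since fluoro in place of methoxy gives a 22-fold lower number from compound 2 to compound 4 (1.34 log units; beyond the scatter), the largest step here. No measurement at hand explains this reversal. The compounds shown leave open whether the lower number belongs to fluoro itself or to the loss of methoxy, which an unsubstituted phenyl or a 4-chlorophenyl on the same chain would help separate.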